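A Methyl Added to the Aromatic Ring of Compound 2

This account rests on a few compounds, and the source may have more. Where it says the series, first, only, none or still open, it means among the compounds named here.

The measured compounds:
Compound 1 `CN(C)CCCN1CCN(CC(=O)Nc2ccc(-c3nc4cc(F)ccc4o3)cc2)CC1` gives 2590 nM in a functional assay on HT-29 cells (Homo sapiens) for cytotoxicity, read by MTT assay, with a stated time of 24 h; on this read-out lower numbers stand for stronger inhibition and higher numbers for weaker inhibition.
Compound 2 `Cc1ccc2oc(-c3ccc(NC(=O)CN4CCN(CCCN(C)C)CC4)cc3)nc2c1` gives 3890 nM in this assay.
Compound 3 `CN(C)CCCN1CCN(CC(=O)Nc2ccc(-c3nc4ccccc4o3)cc2)CC1` gives 10600 nM in this assay.

Compound 2 stands second highest of the three numbers. Its nearest neighbour is reached by a 1.5-fold higher number from compound 1 to compound 2 (0.18 log units; within the scatter), a step within the scatter, so the two cannot be ordered. Its furthest is reached by a 2.7-fold higher number from compound 2 to compound 3 (0.44 log units; beyond the scatter), a modest step, and the largest step among the three is a 4.1-fold higher number from compound 1 to compound 3 (0.61 log units; beyond the scatter).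

Compound 4 `Cc1ccc2oc(-c3ccc(NC(=O)CN4CCN(CCCN(C)C)CC4)c(C)c3)nc2c1` differs from compound 2 by methyl in place of hydrogen on an aromatic carbon. For the measured compounds named here, none of the measured steps bears on this place: all three exchange a group on the six-membered aromatic ring of carbon only that belongs to the other ring system, and the ring touched here is left unchanged in every measured compound. No step beyond the scatter can therefore be expected in this assay from this change, in either direction. The expected step from compound 2 is a 1.2-fold higher number from compound 2 to compound 4 (0.06 log units; within the scatter). Compound 4 is accordingly estimated at 4500 nM, with a range from 1500 nM to 14000 nM.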

Compound 4, half-maximal inhibitory concentration: 12700 nM
The estimate for compound 4 lay 2.8-fold (0.45 log units) below the measured number, and the stated range covers the measured number.
By their numbers in this assay, from the lowest: compounds 1 and 2 (each within the scatter of the next); then compounds 3 and 4 (each within the scatter of the next).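

In this assay methyl in place of hydrogen on the six-membered aromatic ring of carbon only, ortho to a large group and meta to a 5-methyl-1,3-benzoxazol-2-yl group, brings a 3.3-fold higher number from compound 2 to compound 4 (0.51 log units; beyond the scatter) and thus a modest weakening of inhibition. For the compounds shown here, the earlier steps all lay on the other ring system, so this is the first reading from the ring touched here, and it shows that the number responds to a change at this place. Nothing measured on these compounds accounts for the step.

As far as these compounds go, whether a fluoro, chloro or methoxy group at this same place would move the number as far remains open. So does whether methyl on another carbon of this ring, or a hydroxyl group in its place, would do the same.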